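Dropping the methoxy of compound 1: expected growth inhibition

A few compounds are considered here, and "the series" means these few. Any claim that something is new, unique, unknown or untested is made for them only; others in the source may bear on it.

Compound 1 `COc1ccc(CNc2nc([Se]C)nc3ccccc23)cc1` is the reference for this step. In a functional assay on MCF7 cells (Homo sapiens) for cytotoxicity, read by MTT assay, with a stated time of 72 h (a higher number here means a weaker inhibitor of growth, a lower number a stronger inhibitor of growth), compound 1 gives 98600 nM, the highest of the three numbers in hand. Compound 2 `COc1ccc(CNc2nc([SeH])nc3ccccc23)cc1` gives 94000 nM in this assay, and the step of a 1.0-fold lower number from compound 1 to compound 2 (0.02 log units; within the scatter) is within the scatter. For the measured compounds named here, compound 3 `[SeH]c1nc([SeH])c2ccccc2n1` gives 22900 nM in this assay, a number that lies beyond the scatter away from compound 1; no single-point step connects these two.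

Compound 4 `C[Se]c1nc(NCc2ccccc2)c2ccccc2n1` differs from compound 1 by hydrogen in place of methoxy on an aromatic carbon, on an aromatic carbon of a six-membered aromatic ring of carbon only, para to a large group. Going by the values given here, the one measured step, a 1.0-fold lower number from compound 1 to compound 2 (0.02 log units; within the scatter), concerns the selenium substituent and not the aromatic ring, so it does not bear directly on this change; it shows only that a small alteration elsewhere in compound 1 left this assay unmoved. Among the compounds with values here, no measured pair speaks to the methoxy itself. With nothing pointing either way, the step of a 1.1-fold lower number from compound 1 to compound 4 (0.04 log units; within the scatter) is expected to stay within the scatter. Compound 4 is therefore estimated at 90000 nM in this assay, with a range of 40000 nM to 200000 nM.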

Compound 4, concentration for total growth inhibition: 67000 nM
Compound 4: the middle estimate sits 1.3-fold (0.13 log units) above what was measured, within the range that was stated.
By their numbers in this assay, from the lowest: compound 3; then compounds 4, 2 and 1 (each within the scatter of the next).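

In this assay, for the compounds shown here, the step on the aromatic ring is the first reading at this position: a 1.5-fold lower number from compound 1 to compound 4 (0.17 log units; within the scatter) for hydrogen in place of methoxy on an aromatic carbon, para to a large group. The methoxy, with its 2 heavy atoms and 1 hydrogen-bond acceptor, can therefore be lost at this place without a shift beyond the usual scatter, and both single-place changes to compound 1 now leave the reading within that scatter, one on the selenium and one on the aromatic ring. No supporting measurement offers an explanation for this result.

On these data alone, whether the position stays as undemanding with other groups remains open: an amine, a hydroxyl, a carboxylic acid or a longer alkoxy chain in the same place could still move the number beyond the scatter. As far as these compounds go, it is also open whether the same replacement of methoxy by hydrogen would give a similar result on compound 2, with hydrogen rather than methyl on the selenium, as the two changes appear here only separately.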